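A few compounds are considered here, and "the series" means these few. Any claim that something is new, unique, unknown or untested is made for them only; others in the source may bear on it.

Measured so far in an assay on isolated protein for inhibition of alkaline phosphatase, tissue-nonspecific isozyme (Homo sapiens); on this read-out higher numbers stand for weaker inhibition and lower numbers for stronger inhibition:
compound 1, `COc1ccc(Cl)cc1S(=O)(=O)Nc1cncc(-c2ccccc2C)c1`, gives 178 nM;
compound 2, `COc1ccc(S(=O)(=O)Nc2cccnc2)c(OC)c1`, gives 10300 nM.

Of these two numbers compound 1 holds the lower one, and the gap to compound 2 lies well beyond the usual scatter of repeated measurements. The unmeasured compound 3, `COc1ccc(Cl)cc1S(=O)(=O)Nc1cncc(-c2ccc(Cl)cc2)c1`, keeps the core of compound 1 and differs from it in a single place: 4-chlorophenyl in place of 2-methylphenyl on an aromatic carbon. Among the measured compounds shown here, no pair of measured compounds differs in only one place, so no measured step bears directly on this change, and compound 2 differs from compound 1 in several places at once, so its number says nothing separate about the group exchanged here. With nothing in the data pointing either way, the step of a 1.1-fold higher number from compound 1 to compound 3 (0.05 log units; within the scatter) is expected to stay within the scatter. Compound 3 is expected to give 200 nM, with a range from 60 nM to 700 nM.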

Compound 3, half-maximal inhibitory concentration: 198 nM
Compound 3: middle estimate off by 1.0-fold (0.00 log units), on the high side; measured number inside the range.
By their numbers in this assay, from the lowest: compounds 1 and 3 (each within the scatter of the next); then compound 2.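

Within this assay, the exchange of 2-methylphenyl for 4-chlorophenyl gives a 1.1-fold higher number from compound 1 to compound 3 (0.05 log units; within the scatter) and is the first single-place comparison available in this set. On this aromatic carbon, two atoms from the ring nitrogen, the two aryl groups therefore cannot be told apart, even though the methyl of one and the chlorine of the other are different substituents at different places on the ring. Nothing at hand accounts for this likeness between the two groups.

Going by these compounds, what a plain phenyl or a 2-chlorophenyl would give here remains open, and so does whether the methyl and the chlorine each matter separately. Also open, on these data alone, is whether a group of another kind at this carbon, such as a morpholine or a carboxylic acid, would keep the number of compound 1.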